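From Compound 2 to Compound 3: A Larger Side Group

This account rests on a few compounds, and the source may have more. Where it says the series, first, only, none or still open, it means among the compounds named here.

In an ADME assay on HeLa cells (Homo sapiens) for cytotoxicity, read by MTT assay (on this read-out higher numbers stand for weaker inhibition and lower numbers for stronger inhibition), compound 2 `CCN(CC)C(=O)COc1ccc(C[C@H]2C(=O)OC[C@@H]2Cc2ccc(OC)c(OC)c2)cc1OC` gives 188000 nM and compound 1 `COc1ccc(C[C@H]2COC(=O)[C@@H]2Cc2ccc(OCC(=O)N3CCCCC3)c(OC)c2)cc1OC` gives 293000 nM, two values within the usual scatter of each other. Compound 3 `COc1ccc(C[C@H]2COC(=O)[C@@H]2Cc2ccc(OC(=O)CCC(=O)N3CCCCC3)c(OC)c2)cc1OC` differs from compound 2 by this change: a group of 12 heavy atoms (9 carbon, 1 nitrogen, 2 oxygen; one six-membered non-aromatic ring with 1 hetero atom) in place of a group of 8 heavy atoms (6 carbon, 1 nitrogen, 1 oxygen; no ring), on an oxygen on an aromatic ring. Among the compounds with values here, the one measured step, a 1.6-fold lower number from compound 1 to compound 2 (0.19 log units; within the scatter), put diethylamino in place of piperidin-1-yl on a carbonyl carbon and stayed within the scatter. No measurement tests a swap of this size, so the uncertainty is wide, and no shift beyond the scatter is expected in this assay. The expected change is a 1.1-fold higher number from compound 2 to compound 3 (0.03 log units; within the scatter). Compound 3 is estimated at 200000 nM, with a range of 80000 nM to 450000 nM.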

Compound 3, half-maximal inhibitory concentration: 128000 nM
Compound 3: middle estimate off by 1.6-fold (0.19 log units), on the high side; low and high end bracket the measured number.
By their numbers in this assay, from the lowest: compounds 3, 2 and 1 (each within the scatter of the next, the first and the last beyond it).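

In this assay, within the data shown here, the larger group on this oxygen on an aromatic ring leaves the number in place, as a 1.5-fold lower number from compound 2 to compound 3 (0.17 log units; within the scatter) shows, but a 2.3-fold lower number from compound 1 to compound 3 (0.36 log units; beyond the scatter) is the first step here to pass the scatter, if only modestly. The groups in that second step each hold a six-membered non-aromatic ring, so a change that keeps this ring can still shift the number slightly. Nothing available explains either step. As far as these compounds go, whether a carboxylic acid or a simple amine at the end of the group would move the number further remains open, as does the effect of a longer chain.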